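The source may report more compounds than this note shows. Statements on the series, on what has been measured and on what is new or still open speak of the compounds shown alone.

Measured so far in an assay on NIH3T3 cells with Urotensin-2 receptor (Homo sapiens) as the target; a higher number here means that more compound is needed for the effect, a lower number that less compound is needed:
compound 1 `Cc1ccccc1C(=O)NC(CCN(C)C)c1ccc(Cl)cc1`, 3550 nM
compound 2 `COc1ccc(C(=O)NC(CCN(C)C)c2ccc(Cl)cc2)cc1`, 1350 nM
compound 3 `CN(C)CCC(NC(=O)c1ccc(C(F)(F)F)cc1)c1ccc(Cl)cc1`, 77.6 nM

Compound 2 stands second highest of the three numbers in this assay; the step of a 2.6-fold lower number from compound 1 to compound 2 (0.42 log units; beyond the scatter) is the nearer one, the step of a 17-fold lower number from compound 2 to compound 3 (1.24 log units; beyond the scatter) the farther.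

Compound 4 `Cc1cccc(C(=O)NC(CCN(C)C)c2ccc(Cl)cc2)c1C` is not yet measured. It differs from compound 2 in one place: 2,3-dimethylphenyl in place of 4-methoxyphenyl on a carbonyl carbon. Going by the values given here, no measured step swaps exactly these two groups, so the expectation rests on the two neighbouring steps. The entering 2,3-dimethylphenyl resembles the 2-methylphenyl of compound 1 more than it resembles the groups of compound 2 or compound 3, and the step from compound 1 to compound 2 was modest, while the large step to compound 3 concerns a trifluoromethyl that compound 4 does not carry. The step of a 2.2-fold higher number from compound 2 to compound 4 (0.35 log units; beyond the scatter) is therefore expected to run upward, roughly undoing the step from compound 1 to compound 2 rather than matching the larger one. Compound 4 is estimated at 3000 nM in this assay, with a range of 800 nM to 10000 nM.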

Compound 4, half-maximal effective concentration: 3630 nM
For compound 4 the middle estimate is 1.2-fold (0.08 log units) below the measured one; the measured number falls inside the stated range.
By their numbers in this assay, from the lowest: compound 3; then compound 2; then compounds 1 and 4 (each within the scatter of the next).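

In this assay, a 2.7-fold higher number from compound 2 to compound 4 (0.43 log units; beyond the scatter) shows that a carbon-only 2,3-dimethylphenyl on the carbonyl carbon, with no hydrogen-bond acceptor in the group, does not reach the level of the 4-methoxyphenyl. Methyl in place of hydrogen on an aromatic carbon gives a 1.0-fold higher number from compound 1 to compound 4 (0.01 log units; within the scatter) and so adds no step that can be told from the scatter, which places compound 1 and compound 4 level in this series. No available evidence bears on the reason for either step.

On these data alone, it remains open whether a nitrile or a chlorine in place of the trifluoromethyl of compound 3 would keep the low number of that compound. The compounds shown also leave open how a longer chain or a primary amine in place of the dimethylamine end of the shared core would read.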